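Working notes on cytotoxicity across three measured analogues

This account rests on a few compounds, and the source may have more. Where it says the series, first, only, none or still open, it means among the compounds named here.

Measured so far in a toxicity assay on NIH3T3 cells (Mus musculus) for cytotoxicity, read by resazurin assay; a higher number here means that more compound is needed for the effect, a lower number that less compound is needed:
- compound 1 `c1ccc(-c2ccc(Cn3cncc3CNc3ccc(-c4ccc[nH]4)c(-c4ccccc4)c3)cc2)cc1`: > 10000 nM
- compound 2 `c1ccc(Cn2cncc2CNc2cccc(-c3cccnc3)c2)cc1`: > 1000 nM
- compound 3 `Fc1ccc(Cn2cncc2CNc2ccc(-c3nc4ccccc4s3)c(-c3ccccc3)c2)c(F)c1`: > 1000 nM

None of the three values is a number; each is a limit of this assay. Compound 1 stands at the limit of > 10000 nM in this assay, at which 1 of the 3 values shown sits. Compound 2 stands at the limit of > 1000 nM in this assay, at which 2 of the 3 values shown sit. Compound 3 stands at the same limit as compound 2. Every entry is a limit. For the measured compounds named here, no order among compound 1, compound 2 and compound 3 can be read from these data, and no step between measured compounds is available.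

Compound 4 `c1ccc(-c2ccc(Cn3cncc3CNc3ccc(-c4cncs4)c(-c4ccccc4)c3)cc2)cc1` is the next entry for this assay. Relative to compound 1 the change is 1,3-thiazol-5-yl in place of 1H-pyrrol-2-yl on an aromatic carbon. Going by the values given here, with no measured step to lean on, the expectation is that the step that the limit leaves unreadable from compound 1 to compound 4 amounts to nothing beyond the usual scatter, and that compound 4 will most likely again return only a limit. For compound 4 the estimate in this assay is 15000 nM, with the range 5000 nM to 50000 nM expected to hold most repeat measurements.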

Compound 4, half-maximal effective concentration: > 1000 nM
Compound 4: no number, only a limit (the forecaster's own chance of this, stated with the estimate: 85%); the middle value does not contradict the limit.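

For the compounds shown here, compound 1 and compound 4 each return only a limit in this assay, so no step from compound 1 to compound 4 can be read. The compounds shown leave open whether 1,3-thiazol-5-yl in place of 1H-pyrrol-2-yl shifts the read-out at all, and where any of the four compounds would give an actual number.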